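Chloro in Place of tert-Butyl on the Anilide Ring

A few compounds are considered here, and "the series" means these few. Any claim that something is new, unique, unknown or untested is made for them only; others in the source may bear on it.

Measured so far:
compound 1, `Cc1cc(NC(=O)c2ccc(C)c(Nc3nc(-c4cccnc4)cs3)c2)cc(-n2cnc(C)c2)c1`: 3290 nM
compound 2, `Cc1cn(-c2cc(NC(=O)c3ccc(C)c(Nc4nc(-c5cccnc5)cs4)c3)cc(C(C)(C)C)c2)cn1`: 640 nM

In a functional assay on K562 cells (Homo sapiens) for antiproliferative activity (a lower number here means a stronger inhibitor, a higher number a weaker inhibitor), compound 1 gives 3290 nM, while compound 2 gives 640 nM. Going by the values given here, compound 2 therefore stands at the lower of the two numbers, and the only step measured so far, a 5.1-fold lower number from compound 1 to compound 2 (0.71 log units; beyond the scatter), separates it from compound 1. Compound 3, `Cc1cn(-c2cc(Cl)cc(NC(=O)c3ccc(C)c(Nc4nc(-c5cccnc5)cs4)c3)c2)cn1`, carries the change (chloro in place of tert-butyl on an aromatic carbon). Among the compounds with values here, the one measured step bears on it only by analogy: replacing methyl with tert-butyl at this position lowered the number by a modest amount, and chloro is again a single substituent at the same carbon. Whether chloro behaves more like methyl or more like tert-butyl cannot be read from two compounds. The account therefore expects compound 3 to give a number somewhat higher than compound 2, but not the full way back to compound 1, estimated as a 2.3-fold higher number from compound 2 to compound 3 (0.37 log units; beyond the scatter). The estimate for compound 3 in this assay is 1500 nM, expected to lie between 500 nM and 4500 nM.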

Compound 3, half-maximal inhibitory concentration: 2360 nM
Compound 3: the middle estimate sits 1.6-fold (0.20 log units) below what was measured; low and high end bracket the measured number.
By their numbers in this assay, from the lowest: compound 2; then compounds 3 and 1 (each within the scatter of the next).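

In this assay the change to chloro gives a 3.7-fold higher number from compound 2 to compound 3 (0.57 log units; beyond the scatter) and so does not keep the lower number seen with tert-butyl at this carbon. Against methyl, chloro gives a 1.4-fold lower number from compound 1 to compound 3 (0.14 log units; within the scatter) and cannot be told apart from it in this measurement, which leaves tert-butyl as the only one of the three groups whose steps to both others lie beyond the scatter. Nothing available explains why tert-butyl stands apart from chloro and methyl at this position.

The three compounds leave open whether the lower number belongs to tert-butyl alone or would also appear with another branched or multi-atom group at this carbon, such as isopropyl, cyclopropyl or trifluoromethyl. They also leave open how a group carrying an amine or a carboxylic acid would behave here, and whether the ranking of tert-butyl over chloro and methyl would hold if the 4-methyl-1H-imidazol-1-yl group were exchanged for another substituent on the same ring.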